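Swapping a small ring substituent on a pyrazole-type core

This account rests on a few compounds, and the source may have more. Where it says the series, first, only, none or still open, it means among the compounds named here.

Measured so far:
- compound 1, `Cc1cc(NC(=S)Cn2nnc(-c3ccccc3)n2)n(C2CCCCC2)n1`: 623 nM
- compound 2, `Cc1cc(NC(=O)Cn2nnc(-c3ccccc3)n2)n(C2CCCC2)n1`: 163 nM
- compound 3, `CC1CC1c1cc(NC(=O)Cn2nnc(-c3ccccc3)n2)n(C2CCCCC2)n1`: 843 nM

All three were tested in an assay on HEK293 cells for activation of Kir3.1/Kir3.2 (Homo sapiens), read by thallium flux; on this read-out higher numbers stand for an effect only at larger amounts of compound and lower numbers for an effect already at smaller amounts. Among them compound 3 has the highest number, with 843 nM; its gap to compound 1 lies within the usual scatter, while its gap to compound 2 lies beyond it.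

Compound 4, `O=C(Cn1nnc(-c2ccccc2)n1)Nc1cc(C2(C(F)(F)F)CC2)nn1C1CCCCC1`, is not yet measured. It differs from compound 3 in one place: 1-(trifluoromethyl)cyclopropyl in place of 2-methylcyclopropyl on an aromatic carbon. The two rings are of the same kind, and only the group on that ring changes. Within the data shown here, no measured pair shows this exact swap, so there is nothing to anchor a direction. For compound 4 the expected step of a 1.1-fold lower number from compound 3 to compound 4 (0.02 log units; within the scatter) is therefore small, not beyond the scatter. In this assay compound 4 is estimated at 800 nM, within 250 nM to 2500 nM.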

Compound 4, half-maximal effective concentration: "not active" (no number reported)
The entry for compound 4 holds no number; no gap can be computed for the estimate.
By their numbers in this assay, from the lowest: compound 2; then compounds 1 and 3 (each within the scatter of the next).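

Among these compounds, compound 4 is reported as "not active" with no number, so no step from compound 3 to compound 4 can be read. Nothing shown here explains this result. The compounds shown leave open how much activity, if any, compound 4 retains at higher amounts.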